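Replacing the (morpholin-4-yl)carbonyl group of compound 3

The compounds below may be only part of what the source reports. "The series", "measured", "known", "first", "only" and "open" are said of these compounds alone.

In a functional assay (aorta) with Rattus norvegicus as the target (a higher number here means that more compound is needed for the effect, a lower number that less compound is needed), compound 3 `COc1ccc(-c2nc(C(=O)N3CCOCC3)sc2-c2ccc(OC)cc2)cc1` stands only at a limit, < 100 uM. Compound 1 `COc1ccc(-c2nc(/N=C(\N)NC3CCCCC3)sc2-c2ccc(OC)cc2)cc1` also gives only a limit, > 100 uM. Compound 2 `COc1ccc(-c2nc(CNC(C)=O)sc2-c2ccc(OC)cc2)cc1` gives a number, 8.1 uM.

Compound 4 `CCOC(=O)/C=C/c1nc(-c2ccc(OC)cc2)c(-c2ccc(OC)cc2)s1` carries 2-(ethoxycarbonyl)ethenyl in place of (morpholin-4-yl)carbonyl on an aromatic carbon. For the measured compounds named here, the one readable step at this place is large: an at least 12-fold lower number from compound 1 to compound 2 (1.09 log units; beyond the scatter). Going by the values given here, the limits leave a number no higher from compound 1 to compound 3 (the limit leaves the size open) and a step that the limit leaves unreadable from compound 2 to compound 3 open, so no measured step fixes the expected size. Among the compounds with values here, the expectation leans towards compound 2, at 8.1 uM, the only number measured so far.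

The expected change is a step that the limit leaves unreadable from compound 3 to compound 4. Compound 4 is estimated at 20 uM, within an expected range of 4 uM to 100 uM.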

Compound 4, concentration for half-maximal effect: > 100 uM
Compound 4: no number, only a limit; the forecaster's own chance of this, stated with the estimate: 30%; middle value at least 5.0-fold (0.69 log units) from the limit.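

In this assay compound 4 gives only a limit, not a number: the limit of > 100 uM in this assay, at which 2 of the 4 values shown sit. Replacing acetamidomethyl with 2-(ethoxycarbonyl)ethenyl at this position in this assay gives an at least 12-fold higher number from compound 2 to compound 4 (1.09 log units; beyond the scatter), so a large rise occurs here without the ring-bearing group of compound 1. Having no ring in the group is therefore not enough at this place, since both groups in this step have none.

Replacing (morpholin-4-yl)carbonyl with 2-(ethoxycarbonyl)ethenyl in this assay gives a number no lower from compound 3 to compound 4 (the limit leaves the size open). The step to compound 4 from compound 1 cannot be read. From the compounds shown here alone, what a simple amine or a carboxylic acid would give at this position remains open.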